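The source may hold more compounds than are shown below. What is called first, only, known or untested is meant among the compounds shown, and "the series" means these compounds.

The three measured compounds share a cyanoguanidine joined to a phenylthioethyl chain and differ only in the heterocycle at the far end. Compound 1 `Cc1nc(CCCN/C(=N\C#N)NCCSc2ccccc2)c[nH]1` bears a 2-methyl-1H-imidazol-4-yl ring. In a functional assay on Sf9 cells for antagonist activity at histamine H2 receptor (Homo sapiens), read by scintillation counting and GTPgammaS binding, with a stated time of 90 min (on this read-out lower numbers stand for lower potency and higher numbers for higher potency (the scale is a negative logarithm)), compound 1 reports < 5, which is a limit of the assay rather than a number. Within the data shown here, compound 2 `Cc1[nH]cnc1CCCCN/C(=N\C#N)NCCSc1ccccc1` carries a (5-methyl-1H-imidazol-4-yl)methyl group, and in this assay compound 2 gives 5.36, the only plain number among the three, so that a number at least 0.36 log units higher from compound 1 to compound 2 (beyond the scatter). Compound 3 `N#C/N=C(\NCCCCc1cnn[nH]1)NCCSc1ccccc1` carries a 1H-1,2,3-triazol-5-yl ring. In this assay compound 3 reports < 5, again a limit and not a number. Accordingly a number at least 0.36 log units lower from compound 2 to compound 3 (beyond the scatter), whereas a step that the two limits leave unreadable from compound 1 to compound 3 because both ends rest on (the limit of < 5 in this assay, at which 2 of the 3 values shown sit).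

Compound 4 `N#C/N=C(\NCCNc1ccnc(N)n1)NCCSc1ccccc1` is not yet measured. It differs from compound 3 by a group of 8 heavy atoms (4 carbon, 4 nitrogen; one six-membered aromatic ring with 2 hetero atoms) in place of a group of 7 heavy atoms (4 carbon, 3 nitrogen; one five-membered aromatic ring with 3 hetero atoms), on a saturated chain carbon, two bonds along the chain from an amine nitrogen. The measured steps show that swapping the end heterocycle moves potency by at least modest amounts in either direction, and since compound 3 stands at the limit, the step of a number at least 0.60 log units higher from compound 3 to compound 4 (beyond the scatter) is expected only as an upward guess from the edge of the scale. Compound 4 is therefore estimated at 5.6, plausibly between 4.7 and 6.5.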

Compound 4, negative logarithm of the antagonist equilibrium constant: < 5
Compound 4 gave a limit, no number (the forecaster's own chance of this, stated with the estimate: 25%); middle value at least 0.60 log units from the limit.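

Putting the (2-aminopyrimidin-4-yl)amino group in place of the 2-(5-methyl-1H-imidazol-4-yl)ethyl group of compound 2 gives a number at least 0.36 log units lower from compound 2 to compound 4 (beyond the scatter) in this assay. Among these compounds, until now, the only end groups that had failed to give a plain number were five-membered aromatic rings; this result adds a six-membered aromatic ring with 2 hetero atoms, attached on a saturated chain carbon, two bonds along the chain from an amine nitrogen, so compound 2 remains the only one of the four compounds with a plain number. The steps from compound 1 and from compound 3 to compound 4 cannot be read, because both ends of each step rest on the same limit: the limit of < 5 in this assay, at which 3 of the 4 values shown sit.

On these data alone, how compound 1, compound 3 and compound 4 truly rank against one another stays open, as does how much of the value of compound 2 depends on its methyl group. A plain 1H-imidazol-4-yl ring on the same four-carbon chain, or the 2-aminopyrimidin-4-yl ring carried on a longer chain instead of through the amino link, would begin to separate these questions.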